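The source may hold more compounds than are shown below. What is called first, only, known or untested is meant among the compounds shown, and "the series" means these compounds.

Series notes. Among the measured compounds shown here, in an assay for inhibition of Indoleamine 2,3-dioxygenase 1 (Homo sapiens), with stated times of 10 min and 60 min, tested at 10 uM (a higher number here means a stronger effect of the compound at the concentration tested, a lower number a weaker effect), compound 2 `O=[N+]([O-])c1ccc(CNc2cc(Br)cc3[nH]ncc23)cc1` gives 63%, the highest of the three numbers so far. Compound 3 `O=[N+](O)c1c(Cl)cccc1CNc1cc(C(F)(F)F)cc2[nH]ncc12` gives 45% in this assay, a reading below compound 2 by more than the usual scatter. Compound 1 `Oc1ccc(CNc2cc(C(F)(F)F)cc3[nH]ncc23)cc1` gives 37% in this assay, the furthest from compound 2, again beyond the scatter. Compound 4 `O=[N+]([O-])c1ccc(CNc2cc(C(F)(F)F)cc3[nH]ncc23)cc1` has not been measured; its difference from compound 2 is trifluoromethyl in place of bromo on an aromatic carbon. For the measured compounds named here, no pair of measured compounds differs in this one place, so no measured step guides the change. Compound 1 and compound 3, which both carry the trifluoromethyl, sit lower than compound 2, though they also differ elsewhere. A step downward of roughly the size of the scatter is expected, a number 11 percentage points lower from compound 2 to compound 4 (beyond the scatter). Compound 4 is estimated at 52% in this assay, between 32% and 70%.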

Compound 4, a percentage reported as inhibition, at one concentration (the size of the read-out at that concentration, not a potency): 52%
Beside the measured number, compound 4's estimate shows no gap at the digits printed, within the range that was stated.
By their numbers in this assay, from the lowest: compounds 1, 3 and 4 (each within the scatter of the next, the first and the last beyond it); then compound 2.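

In this assay, trifluoromethyl in place of bromo now has a one-place reading at this position, with the rest of the structure held: a number 11 percentage points lower from compound 2 to compound 4 (beyond the scatter). The loss seen before only across compounds that also differed elsewhere is thus confirmed for this change alone, as a modest step. A second one-place reading, nitro in place of hydroxy on an aromatic carbon, gives a number 15 percentage points higher from compound 1 to compound 4 (beyond the scatter).

Nothing available explains either step. Going by these compounds, how a nitrile at the bromo position, or an amine in place of the nitro, would read remains open.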